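The source may hold more compounds than are shown below. What is called first, only, known or untested is meant among the compounds shown, and "the series" means these compounds.

Measured so far in an ADME assay on RAW264.7 cells (Mus musculus) for cytotoxicity, read by WST assay; on this read-out higher numbers stand for lower toxicity in this test and lower numbers for higher toxicity in this test:
compound 1 `O=C(c1ccc(CN2Cc3ccccc3C2=O)cc1)N1CCCCC1` — > 100000 nM
compound 2 `CC(C)(C)OC(=O)N(Cc1ccco1)C(=O)c1ccc(Cn2sc3ccccc3c2=O)cc1` — > 100000 nM
compound 3 `CC(C)(C)OC(=O)N(C(=O)OC(C)(C)C)C(=O)c1ccc(CN2C(=O)c3ccccc3S2(=O)=O)cc1` — > 100000 nM

Each of these three values is a limit of the assay, not a number. In this assay compound 3 therefore gives only a limit, and it does not stand apart from the others: the limit of > 100000 nM in this assay, at which 3 of the 3 values shown sit. Compound 4 `CC(C)(C)OC(=O)N(Cc1ccco1)C(=O)c1ccc(CN2C(=O)c3ccccc3S2(=O)=O)cc1` differs from compound 3 in one place: (furan-2-yl)methyl in place of tert-butoxycarbonyl on an amide-type nitrogen. Compound 2 already carries the (furan-2-yl)methyl group, and its reading in this assay is likewise a limit. Among the measured compounds shown here, no measured pair shows how such a change moves this reading, so no step beyond the scatter is expected in either direction. Compound 4 is therefore expected to give 100000 nM, between 50000 nM and 300000 nM. The expected step of a number no higher from compound 3 to compound 4 (the limit leaves the size open) would leave the reading at the limit.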

Compound 4, concentration lethal to 50% of the cells: > 100000 nM
Compound 4 gave a limit, no number; the forecaster's own chance of this, stated with the estimate: 80%; the middle value lies on the limit itself.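

Among the compounds shown here, compound 3 and compound 4 both give only a limit in this assay, so no step between them can be read. The compounds shown leave open whether any change among them moves this reading at all: the limit of > 100000 nM in this assay, at which 4 of the 4 values shown sit.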